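Swapping the Amine Substituent: An Expectation for Compound 3

The compounds below may be only part of what the source reports. "The series", "measured", "known", "first", "only" and "open" are said of these compounds alone.

Compound 1 `CCN(Cc1ccc(Br)cc1)c1cccc(C(=O)N2CCc3ccc(OS(N)(=O)=O)cc3C2)c1` gives 84.5% in an assay on HEK293 cells for inhibition of Steryl-sulfatase (Homo sapiens), tested at 1 uM; a lower number here means a weaker effect, a higher number a stronger effect of the compound at the concentration tested.
Compound 2 `CCN(Cc1ccccn1)c1cccc(C(=O)N2CCc3ccc(OS(N)(=O)=O)cc3C2)c1` gives 19.9% in this assay.

Within the data shown here, compound 2 stands lowest of the two numbers measured; its only neighbour, compound 1, lies far above it, and the single measured step, a number 64.6 percentage points lower from compound 1 to compound 2 (beyond the scatter), came with pyridin-2-yl in place of 4-bromophenyl on a saturated chain carbon bound to a nitrogen on an aromatic ring.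

Compound 3 `CN(CCN1CCCCC1)c1cccc(C(=O)N2CCc3ccc(OS(N)(=O)=O)cc3C2)c1` has not yet been measured. It differs from compound 2 by methyl(2-(piperidin-1-yl)ethyl)amino in place of ethyl((pyridin-2-yl)methyl)amino on an aromatic carbon. Among the measured compounds shown here, the one measured step bears on this change only loosely: it shows that what sits on this nitrogen can move the read-out a great deal, but it compared two aromatic rings, whereas compound 3 replaces the aromatic ring with a non-aromatic one. Compound 2 is already near the bottom, so a large further fall has little room, and nothing measured points to a rise. The step from compound 2 to compound 3 is therefore expected to be a number 2.1 percentage points higher from compound 2 to compound 3 (within the scatter), within the usual scatter. Compound 3 is estimated at 22%, with a range from 3% to 55%.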

Compound 3, a percentage reported as inhibition, at one concentration (the size of the read-out at that concentration, not a potency): 30.8%
Compound 3: middle estimate off by 8.8 percentage points, on the low side, and the stated range covers the measured number.
By their numbers in this assay, from the lowest: compound 2; then compound 3; then compound 1.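

In this assay, replacing ethyl((pyridin-2-yl)methyl)amino with methyl(2-(piperidin-1-yl)ethyl)amino on this aromatic carbon gives a number 10.9 percentage points higher from compound 2 to compound 3 (beyond the scatter), so a group ending in a six-membered non-aromatic ring does not lower the read-out further and in fact lifts it modestly. The other new comparison gives a number 53.7 percentage points lower from compound 1 to compound 3 (beyond the scatter), which shows that an aromatic ring in this group does not alone decide the outcome: compound 1 and compound 2 both carry one, yet compound 3, which has none, falls between them. Nothing measured here explains these differences.

The change from compound 2 to compound 3 alters the small group on the nitrogen, the link to the ring and the ring itself all at once, so the contribution of each part remains unresolved. On these data alone, it also remains open whether the high read-out of compound 1 depends on the bromine or on the benzene ring that carries it, a question that a plain benzyl group or a 4-chlorobenzyl group on the same nitrogen would address.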